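Swapping fluoro for bromo on the ketone-bearing ring

The source may report more compounds than this note shows. Statements on the series, on what has been measured and on what is new or still open speak of the compounds shown alone.

Of the compounds shown here, two have been tested in a functional assay on the whole organism (Ear) for inhibition, with Mus musculus as the target, with a stated time of 30 min, at a dose of 100 mg/kg by the intraperitoneal route; on this read-out higher numbers stand for more inhibition at the one dose given (going by the name of the read-out) and lower numbers for less inhibition. Compound 1, `Cc1ccc(C(=O)/C=C/c2ccc(/C=N/NC(=O)c3ccccc3)cc2)c(C)c1`, gives 0.18%. Compound 2, `O=C(/C=C/c1ccc(/C=N/NC(=O)c2ccncc2)cc1)c1ccc(F)cc1`, gives 51.1%. Among the measured compounds shown here, on the numbers so far, compound 2 stands highest of the two, and its nearest neighbour, compound 1, lies far enough below it that the gap is beyond the usual scatter of this assay.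

Compound 3, `O=C(/C=C/c1ccc(/C=N/NC(=O)c2ccncc2)cc1)c1ccc(Br)cc1`, has not yet been measured. It differs from compound 2 in one place: bromo in place of fluoro on an aromatic carbon. For the measured compounds named here, no measured pair shows the effect of this particular swap, so there is no step to lean on. Because compound 2 reaches 51.1% with the fluoro group in that position, the expectation is that compound 3 lands in a similar region, with a step from compound 2 to compound 3 of a number 3.1 percentage points lower from compound 2 to compound 3 (within the scatter), which is not expected to go beyond the scatter in either direction. Compound 3 is therefore estimated at 48%, within a range from 22% to 74%.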

Compound 3, a percentage reported as inhibition, in the whole organism at one dose (the size of the read-out at that dose, not a potency): 55.7%
Compound 3: the middle estimate sits 7.7 percentage points below what was measured, within the range that was stated.
By their numbers in this assay, from the lowest: compound 1; then compounds 2 and 3 (each within the scatter of the next).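

Among the compounds shown here, this is the first comparison in the set that changes only one place, since compound 1 differs from the other two in more than one. With 4-fluorophenyl exchanged for 4-bromophenyl, the step in this assay reads a number 4.6 percentage points higher from compound 2 to compound 3 (within the scatter), so this read-out does not separate the two halogens at this position, and bromo serves there as well as fluoro at the one dose given. No measurement shown offers an explanation for this result.

The compounds shown leave open whether a group other than a halogen, such as an amine, a methoxy group or a carboxylic acid, would hold up equally well at this position. They also leave open which of the differences between compound 1 and the others goes with its much lower number.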